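The compounds below may be only part of what the source reports. "The series", "measured", "known", "first", "only" and "open" are said of these compounds alone.

Compound 1 `O=C(/C=C/c1ccc2c(c1)B(O)OC2)c1ccc(F)cc1` is the anchor of this small set. Within the data shown here, in a toxicity assay on WI-38 cells (Homo sapiens) for cytotoxicity, read by MTT assay, with a stated time of 48 h (on this read-out lower numbers stand for stronger inhibition and higher numbers for weaker inhibition), compound 1 gives 7600 nM, and this is the only number the set offers. Compound 2 `O=C(/C=C/c1ccc2c(c1)B(O)OC2)c1ccccc1O`, in which the aryl group on the carbonyl carbon is changed, returns in this assay only > 100000 nM, a limit of the assay rather than a number. Among the measured compounds shown here, the one measured step, an at least 13-fold higher number from compound 1 to compound 2 (1.11 log units; beyond the scatter), therefore points to a sharp loss on changing that aryl group, with the reading sitting at the limit of > 100000 nM in this assay, at which 1 of the 2 values shown sits.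

Compound 3 `O=C(O)c1ccc(C(=O)/C=C/c2ccc3c(c2)B(O)OC3)cc1` differs from compound 1 by carboxy in place of fluoro on an aromatic carbon. For the measured compounds named here, the single measured step concerns the same aryl group on the carbonyl carbon and was large, so a change at that ring is expected to shift the read-out substantially, upward. Compound 3 is accordingly expected to show a 3.9-fold higher number from compound 1 to compound 3 (0.60 log units; beyond the scatter) in this assay. The estimate for compound 3 is 30000 nM, expected to lie between 8000 nM and 100000 nM, with a fair chance that only a limit is reported.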

Compound 3, half-maximal inhibitory concentration: > 100000 nM
Compound 3: only a limit was reported; the forecaster's own chance of this, stated with the estimate: 35%; middle value at least 3.3-fold (0.52 log units) from the limit.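

The earlier step replaced one substituted aryl group with another, whereas this one changes only the group on the aromatic carbon that carries fluoro in compound 1, para to a large group. Carboxy in place of fluoro there gives an at least 13-fold higher number from compound 1 to compound 3 (1.11 log units; beyond the scatter) in this assay, which shows that a change at this single position is enough on its own to raise the number well beyond the scatter. The reading for compound 3 is a limit and not a number, so the step gives only a minimum size, and compound 1 remains the one compound in the set with a measured value: the limit of > 100000 nM in this assay, at which 2 of the 3 values shown sit.

The compounds shown leave open whether the rise belongs to carboxy in particular or would follow any replacement of fluoro at this position, a question that a methyl ester, an amine or a chlorine atom in the same place could begin to settle. They also leave open whether a plain hydrogen there would keep a measurable number in this assay, and so how much fluoro itself contributes to the value of compound 1.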